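A few compounds are considered here, and "the series" means these few. Any claim that something is new, unique, unknown or untested is made for them only; others in the source may bear on it.

Compound 1 `COc1nc(N)nc2c1c(-c1ccsc1)cn2[C@@H]1O[C@H](CO)[C@@H](O)[C@H]1O` is measured in a functional assay on CCRF-CEM cells (Homo sapiens), read by MTT assay, with a stated time of 72 h; a lower number here means a stronger inhibitor, a higher number a weaker inhibitor: compound 1 gives > 20000 nM, which is a limit of the assay and not a number.
Compound 2 `COc1nc(N)nc2c1c(-c1cccs1)cn2[C@@H]1O[C@H](CO)[C@@H](O)[C@H]1O` is measured too, and in this assay compound 2 gives > 20000 nM, again a limit of the assay.
Compound 3 `CNc1ncnc2c1c(-c1cccs1)cn2[C@@H]1O[C@H](CO)[C@@H](O)[C@H]1O` is the third; in this assay compound 3 gives > 20000 nM, also a limit of the assay.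

Compound 2 and compound 1 differ in one place: thiophen-3-yl in place of thiophen-2-yl on an aromatic carbon. The step that the two limits leave unreadable from compound 2 to compound 1 cannot be read in size, because the limit of > 20000 nM in this assay, at which 3 of the 3 values shown sit, holds both ends of it. The difference between the core of compound 2 and the core of compound 3 is not broken down here.

Compound 4 `CNc1ncnc2c1c(-c1ccsc1)cn2[C@@H]1O[C@H](CO)[C@@H](O)[C@H]1O` is not yet measured. It stands to compound 3 as compound 1 stands to compound 2: thiophen-3-yl in place of thiophen-2-yl on an aromatic carbon. The two places are the same word for word, so this is the same change. Because the limit of > 20000 nM in this assay, at which 3 of the 3 values shown sit, is where every measured value sits, the step from compound 3 to compound 4 is expected to stay at that limit, a step that the limit leaves unreadable from compound 3 to compound 4, with nothing to show any shift. For compound 4 in this assay the estimate is 40000 nM, expected between 15000 nM and 150000 nM.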

Compound 4, half-maximal inhibitory concentration: > 20000 nM
Compound 4: only a limit was reported; the forecaster's own chance of this, stated with the estimate: 85%; the middle value does not contradict the limit.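

In this assay compound 4 gives > 20000 nM as a limit of the assay and not a number. No size can be read for the step between compound 3 and compound 4, because both ends rest on the same limit: the limit of > 20000 nM in this assay, at which 4 of the 4 values shown sit.
The compounds shown leave open whether thiophen-3-yl in place of thiophen-2-yl changes activity at all.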